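Methyl added to a bicyclic carboxamide inhibitor

This account rests on a few compounds, and the source may have more. Where it says the series, first, only, none or still open, it means among the compounds named here.

Measured compounds:
compound 1 `O=C1NCCc2ncccc21` — no value in this assay
compound 2 `NC(=O)c1cnc2c(c1)CCN2` — 175 nM
compound 3 `NC(=O)c1cnc2[nH]ccc2c1Cl` — > 10000 nM

In an assay on isolated protein for inhibition of Nicotinamide N-methyltransferase (Homo sapiens), read by luminescence, with a stated time of 20 min (a lower number here means a stronger inhibitor, a higher number a weaker inhibitor), compound 2 gives 175 nM. Among the compounds with values here, this is the only single number in the set. For compound 1 the entry in this assay reads no result reported. Compound 3 gives > 10000 nM, which is a limit of the assay and not a number; it sits at the limit of > 10000 nM in this assay, at which 1 of the 3 values shown sits. Within the data shown here, with one number and one limit, no step between measured compounds can be stated, and nothing is known about how the methyl of compound 4 might act.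

Compound 4 `Cc1c(C(N)=O)cnc2c1CCN2` differs from compound 2 by methyl in place of hydrogen on an aromatic carbon, a change on an aromatic carbon of the six-membered ring, ortho to a carbamoyl group and ortho to a fused ring. The author expects a modest loss for compound 4 in this assay, roughly at or a little beyond the scatter, but the direction is uncertain. The step from compound 2 to compound 4 is estimated at a 2.6-fold higher number from compound 2 to compound 4 (0.41 log units; beyond the scatter). Compound 4 is expected to give about 450 nM in this assay, with a range from 120 nM to 2500 nM.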

Compound 4, half-maximal inhibitory concentration: 102 nM
Beside the measured number, compound 4's estimate is 4.4-fold (0.64 log units) above it, outside the stated range (below it).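

At the aromatic carbon opposite the ring nitrogen, ortho to a carbamoyl group and ortho to a fused ring, methyl in place of hydrogen leaves the reading in this assay unresolved from that of the parent: the step is a 1.7-fold lower number from compound 2 to compound 4 (0.23 log units; within the scatter), so the two values cannot be told apart. Within the data shown here, the earlier compounds offered only one number and no step, so this pair gives the first direct reading of this position, and it shows that the position can carry a methyl with inhibition retained in the same range. Nothing measured here accounts for the size of this step.

Whether the position accepts anything beyond methyl stays open, since an ethyl group, a methoxy group, an amine or a carboxylic acid at this carbon is not among the compounds shown, and one step on one core supports no wider pattern. Compound 3 gives > 10000 nM, a limit of the assay and not a number, and it differs from compound 2 in more than one place, so it does not settle this question.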